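From propanoyloxy to propoxy on the shared core

A few compounds are considered here, and "the series" means these few. Any claim that something is new, unique, unknown or untested is made for them only; others in the source may bear on it.

In a functional assay on A549 cells (Homo sapiens) for cytotoxicity, with a stated time of 48 h (on this read-out lower numbers stand for stronger inhibition and higher numbers for weaker inhibition), compound 1 `Cc1ccc2oc(/C=C/[S+](C)[O-])cc(=O)c2c1` gives 1700 nM, compound 2 `C[S+]([O-])/C=C/c1cc(=O)c2cc(Cl)ccc2o1` gives 1700 nM and compound 3 `CCC(=O)Oc1ccc2oc(/C=C/[S+](C)[O-])cc(=O)c2c1` gives 2400 nM. The measured steps all stay within the scatter: no change at the digits printed from compound 1 to compound 2 (within the scatter), a 1.4-fold higher number from compound 1 to compound 3 (0.15 log units; within the scatter) and a 1.4-fold higher number from compound 2 to compound 3 (0.15 log units; within the scatter). Compound 3 is therefore not separated from either of the other two compounds.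

Compound 4 `CCCOc1ccc2oc(/C=C/[S+](C)[O-])cc(=O)c2c1` carries one change relative to compound 3: propyl in place of propanoyl on an oxygen on an aromatic ring. This places propyl in place of propanoyl on an oxygen on an aromatic ring. For the measured compounds named here, no measured step makes this exact exchange, and no compound with propoxy has been measured yet. The closest evidence is the pair of steps that introduce propanoyloxy in compound 3, a 1.4-fold higher number from compound 1 to compound 3 (0.15 log units; within the scatter) and a 1.4-fold higher number from compound 2 to compound 3 (0.15 log units; within the scatter). Neither exceeds the scatter, so no step beyond the scatter is expected in this assay. The expected step is a 1.2-fold lower number from compound 3 to compound 4 (0.08 log units; within the scatter). For compound 4 the estimated value is 2000 nM, with an expected range from 900 nM to 4500 nM.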

Compound 4, half-maximal inhibitory concentration: 1100 nM
Compound 4: the middle estimate sits 1.8-fold (0.26 log units) above what was measured, and the stated range covers the measured number.
By their numbers in this assay, from the lowest: compounds 4, 1, 2 and 3 (each within the scatter of the next, the first and the last beyond it).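

In this assay, for the compounds shown here, the exchange on this oxygen on an aromatic ring gives the only step beyond the scatter, a modest one: a 2.2-fold lower number from compound 3 to compound 4 (0.34 log units; beyond the scatter) with propyl in place of propanoyl. Propoxy is not separated from the groups on the aromatic carbon of the other two compounds, with a 1.5-fold lower number from compound 2 to compound 4 (0.19 log units; within the scatter) for propoxy in place of chloro and a 1.5-fold lower number from compound 1 to compound 4 (0.19 log units; within the scatter) for propoxy in place of methyl, so only propanoyloxy and propoxy are told apart here. Nothing on hand explains the difference between propyl and propanoyl at this place.

The compounds shown leave open whether the step follows the carbonyl of propanoyl or the chain itself. A free hydroxy, an acetyloxy or a butoxy on the same oxygen would bear on that question.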